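The source may hold more compounds than are shown below. What is called first, only, known or untested is meant among the compounds shown, and "the series" means these compounds.

Measured so far in a functional assay on MKN-45 cells (Homo sapiens) for cytotoxicity, read by MTT assay, with a stated time of 72 h; a lower number here means a stronger inhibitor, a higher number a weaker inhibitor:
compound 1 `COc1cc2c(Oc3ccc(NC(=O)c4cc(-c5ccccc5)nc5ccccc45)cc3F)ccnc2cc1OCCCN1CCCCC1` — 15 nM
compound 2 `COc1cc2c(Oc3ccc(NC(=O)c4cc(-c5ccc(F)cc5)nc5ccccc45)cc3F)ccnc2cc1OCCCN1CCCCC1` — 28 nM
compound 3 `COc1cc2c(Oc3ccc(NC(=O)c4cc(-c5ccccc5)nc5ccccc45)cc3F)ccnc2cc1OCCCN1CCC(C)CC1` — 19 nM

Compound 3 stands second highest of the three numbers; its nearest neighbour is compound 1 and its furthest compound 2, and both gaps are within the scatter. Compound 4 `COc1cc2c(Oc3ccc(NC(=O)c4cc(-c5ccc(C)cc5)nc5ccccc45)cc3F)ccnc2cc1OCCCN1CCC(C)CC1` differs from compound 3 by methyl in place of hydrogen on an aromatic carbon. Going by the values given here, the only measured step that bears on this change is the one on the same aromatic ring, para to a large group, a 1.9-fold higher number from compound 1 to compound 2 (0.27 log units; within the scatter), which did not leave the scatter. A similar step is therefore expected here, a 1.4-fold higher number from compound 3 to compound 4 (0.14 log units; within the scatter), a small shift toward a higher number, not clearly beyond the scatter. Compound 4 is estimated at 26 nM, with a range from 12 nM to 55 nM.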

Compound 4, half-maximal inhibitory concentration: 770 nM
Compound 4: the middle estimate sits 30-fold (1.47 log units) below what was measured; measured number above the stated range.
By their numbers in this assay, from the lowest: compounds 1, 3 and 2 (each within the scatter of the next); then compound 4.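

In this assay, going by these compounds alone, the change to 4-methylphenyl is the first to leave the scatter (a 41-fold higher number from compound 3 to compound 4 (1.61 log units; beyond the scatter)). The fluoro change on the same ring, para to a large group, stayed within the scatter (a 1.9-fold higher number from compound 1 to compound 2 (0.27 log units; within the scatter)), so at this position the outcome depends on which group enters. Nothing measured here bears on the reason for the large step.

As far as these compounds go, the fluoro step was read without the methyl on the saturated ring, so it remains open whether the methyl step depends on that group. Also open, from the compounds shown here alone, is whether chloro, methoxy or ethyl at this position follows fluoro or methyl.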